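This account rests on a few compounds, and the source may have more. Where it says the series, first, only, none or still open, it means among the compounds named here.

Among the compounds with values here, compound 2 `COc1ccc(CN([C@@H]2CC(F)(F)CCNC2=O)S(=O)(=O)c2ccc(Cl)cc2)c(F)c1F` gives 19 mL.min-1.g-1 in an in vitro ADME assay on microsomes (Homo sapiens) for pharmacokinetics (a higher number here means faster removal of the compound, a lower number slower removal), the highest of the two numbers known; compound 1 `COc1ccc(CN([C@@H]2CC(F)(F)CCNC2=O)S(=O)(=O)c2ccc(Cl)cc2)cn1` gives 9 mL.min-1.g-1 in this assay. Within the data shown here, the single measured step, a 2.1-fold higher number from compound 1 to compound 2 (0.32 log units; beyond the scatter), exchanges the whole aryl group and bears only loosely on the next change. Compound 3 `COc1ccc(CN([C@@H]2CC(F)(F)CCNC2=O)S(=O)(=O)c2ccc(Cl)cc2)c(F)c1` differs from compound 2 by hydrogen in place of fluoro on an aromatic carbon. Among the measured compounds shown here, no measured step removes one fluoro alone, so a step no larger than the scatter is expected, a 1.3-fold lower number from compound 2 to compound 3 (0.10 log units; within the scatter). Compound 3 is therefore estimated at 15 mL.min-1.g-1, within a range of 8 mL.min-1.g-1 to 28 mL.min-1.g-1.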

Compound 3, intrinsic clearance in microsomes: 13 mL.min-1.g-1
Compound 3: the middle estimate sits 1.2-fold (0.06 log units) above what was measured, and the stated range covers the measured number.
By their numbers in this assay, from the lowest: compounds 1, 3 and 2 (each within the scatter of the next, the first and the last beyond it).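

In this assay, the fluoro ortho to a methoxy group can give way to hydrogen with a change inside the scatter (a 1.5-fold lower number from compound 2 to compound 3 (0.16 log units; within the scatter)). Compound 3 also stays within the scatter of the pyridine-bearing compound (a 1.4-fold higher number from compound 1 to compound 3 (0.16 log units; within the scatter)), although the difluoro compound does not. The compounds shown carry no data that explain either step.

Open, on these data alone, is whether chloro or a nitrile on this aromatic carbon would give a step beyond the scatter. Also open, as far as these compounds go, is how a 4-methoxyphenyl group carrying no fluoro would read.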